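The compounds below may be only part of what the source reports. "The series", "measured", "known", "first", "only" and "open" are said of these compounds alone.

Among the compounds with values here, compound 3, with the structure `O=[N+]([O-])c1cc(S(=O)(=O)C(Cl)(Cl)Br)ccc1NCc1ccco1`, stands second highest of the three numbers so far in an assay on cells for inhibition of serine/threonine-protein kinase WNK1 (Homo sapiens), read by luminescence and Kinase-Glo, with a stated time of 2 h; on this read-out lower numbers stand for stronger inhibition and higher numbers for weaker inhibition: compound 3 gives 15000 nM. Its nearest neighbour is compound 1, `O=[N+]([O-])c1cc(S(=O)(=O)C(Cl)(Cl)Br)ccc1NC1CCCCC1`, which in this assay gives 4000 nM, and the furthest is compound 2, `O=[N+]([O-])c1cc(S(=O)(=O)C(Cl)(Cl)Br)ccc1Nc1ccccc1`, which gives 76000 nM. The step from compound 1 to compound 3 was a 3.8-fold higher number from compound 1 to compound 3 (0.57 log units; beyond the scatter), and the step from compound 2 to compound 3 was a 5.1-fold lower number from compound 2 to compound 3 (0.70 log units; beyond the scatter), so the group on the nitrogen has moved the number in both directions beyond the scatter.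

Compound 4 is `O=[N+]([O-])c1cc(S(=O)(=O)C(Cl)(Cl)Br)ccc1NCCCCc1ccccc1`. The change from compound 3 is 3-phenylpropyl in place of furan-2-yl on a saturated chain carbon bound to a nitrogen on an aromatic ring. The measured steps show that a saturated group on this nitrogen, as in compound 1 with 4000 nM, sits lower than an aromatic ring attached directly, as in compound 2. The new group brings a saturated chain between the nitrogen and the ring, so a modest step downward is expected, estimated as a 1.9-fold lower number from compound 3 to compound 4 (0.27 log units; within the scatter). Compound 4 is therefore expected to give about 8000 nM, with a range from 2500 nM to 30000 nM.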

Compound 4, half-maximal inhibitory concentration: 79000 nM
Beside the measured number, compound 4's estimate is 9.9-fold (0.99 log units) below it; measured number above the stated range.
By their numbers in this assay, from the lowest: compound 1; then compound 3; then compounds 2 and 4 (each within the scatter of the next).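

Replacing furan-2-yl with 3-phenylpropyl on the saturated chain carbon gives a 5.3-fold higher number from compound 3 to compound 4 (0.72 log units; beyond the scatter) in this assay, so a saturated chain carbon bound to the nitrogen does not by itself keep the number low. Compound 4 goes against the lower number seen with the saturated cyclohexyl group of compound 1, and its value lies within the scatter of that of compound 2, which carries phenyl directly on the nitrogen. Nothing given here accounts for this rise.

The compounds shown do not separate the effect of the longer chain from that of the phenyl ring at its end. As far as these compounds go, a benzyl group, or a plain butyl chain with no ring, would be needed on this nitrogen to tell the two apart, and an amine or a carboxylic acid at the chain end remains open as well.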